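A few compounds are considered here, and "the series" means these few. Any claim that something is new, unique, unknown or untested is made for them only; others in the source may bear on it.

Of the compounds shown here, three built on a shared core have so far been tested in a functional assay on KYSE-70 cells for antiproliferative activity against KYSE-70 cell line (Homo sapiens), read by MTT assay, with a stated time of 72 h; a lower number here means a stronger inhibitor, a higher number a weaker inhibitor. Compound 1 `COc1ccc(NC(=O)c2cc(=O)[nH]c3cc(Br)ccc23)cc1` gives only a limit of the assay, > 20000 nM. Compound 2 `CC(C)(C)c1ccc(NC(=O)c2cc(=O)[nH]c3cc(Br)ccc23)cc1` likewise gives a limit, > 20000 nM. The step that the two limits leave unreadable from compound 1 to compound 2 is therefore unreadable. Compound 3 `CC(=O)c1ccc(-c2ccc3c(C(=O)Nc4cccc(F)c4)cc(=O)[nH]c3c2)cc1` also gives a limit in this assay, namely > 20000 nM. Among the measured compounds shown here, compound 3 thus stands where every value so far sits, at the limit of > 20000 nM in this assay, at which 3 of the 3 values shown sit, and no number separates it from compounds 1 and 2.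

Compound 4 `O=C(Nc1cccc(F)c1)c1cc(=O)[nH]c2cc(-c3ccc(F)c(CO)c3)ccc12` has not yet been measured. It differs from compound 3 in one place: 4-fluoro-3-(hydroxymethyl)phenyl in place of 4-acetylphenyl on an aromatic carbon. For the measured compounds named here, no measured step bears readably on this change, as the only step available, a step that the two limits leave unreadable from compound 1 to compound 2, is hidden by the limits on both sides. With nothing but limits to go on, no step beyond the scatter is expected in either direction, so the step of a number no higher from compound 3 to compound 4 (the limit leaves the size open) is expected to be small. Compound 4 is therefore estimated at 20000 nM. For compound 4 the expected range runs from 5000 nM to 60000 nM.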

Compound 4, half-maximal inhibitory concentration: > 20000 nM
Compound 4: no number, only a limit; the forecaster's own chance of this, stated with the estimate: 70%; the middle value sits exactly at the limit.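

Compound 3 and compound 4 each give only a limit, so swapping 4-acetylphenyl for 4-fluoro-3-(hydroxymethyl)phenyl yields no readable step. The compounds shown leave open which change to the shared core would give an actual number in this assay, because all of them sit at one limit: the limit of > 20000 nM in this assay, at which 4 of the 4 values shown sit.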